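A few compounds are considered here, and "the series" means these few. Any claim that something is new, unique, unknown or untested is made for them only; others in the source may bear on it.

Measured so far in a functional assay on PC-3 cells (Homo sapiens) for cytotoxicity, read by MTT assay, with a stated time of 72 h; on this read-out lower numbers stand for stronger inhibition and higher numbers for weaker inhibition:

- compound 1 `FC(F)(F)c1ccc(CSc2nc(Nc3ccccc3Cl)c3ccccc3n2)cc1` gives 20400 nM
- compound 2 `CCOc1ccccc1Nc1nc(SCc2ccc(C(F)(F)F)cc2)nc2ccccc12` gives 26200 nM
- compound 3 `FC(F)(F)c1ccc(CSc2nc(Nc3cccc(Cl)c3)c3ccccc3n2)cc1` gives 13400 nM

Compound 1 has the second highest of these three numbers. Its nearest neighbour is compound 2, a change of a 1.3-fold higher number from compound 1 to compound 2 (0.11 log units; within the scatter), and the step to compound 3 is a 1.5-fold lower number from compound 1 to compound 3 (0.18 log units; within the scatter); both lie within the scatter of repeated measurements. The step between the other two, a 2.0-fold lower number from compound 2 to compound 3 (0.29 log units; within the scatter), is also within the scatter. All three compounds share the same core and differ only in the group carried on the nitrogen attached to it.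

Compound 4 `FC(F)(F)c1ccc(CSc2nc(Nc3ccc(C(F)(F)F)cc3)c3ccccc3n2)cc1` has not yet been measured. It differs from compound 1 in one place: 4-(trifluoromethyl)phenyl in place of 2-chlorophenyl on a nitrogen on an aromatic ring. The three measured steps are the ones that bear on this change, as each of them also swaps the group on that nitrogen, and none of them moved the number beyond the scatter. On that basis compound 4 is expected to show no clear step from compound 1, a 1.3-fold lower number from compound 1 to compound 4 (0.11 log units; within the scatter). The estimate for compound 4 in this assay is 16000 nM, with a range from 6000 nM to 45000 nM.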

Compound 4, half-maximal inhibitory concentration: 7880 nM
Beside the measured number, compound 4's estimate is 2.0-fold (0.31 log units) above it, and the stated range covers the measured number.
By their numbers in this assay, from the lowest: compounds 4, 3, 1 and 2 (each within the scatter of the next, the first and the last beyond it).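

In this assay the group on the nitrogen now moves the number beyond the scatter: 4-(trifluoromethyl)phenyl gives modest steps against 2-chlorophenyl (a 2.6-fold lower number from compound 1 to compound 4 (0.41 log units; beyond the scatter)) and against 2-ethoxyphenyl (a 3.3-fold lower number from compound 2 to compound 4 (0.52 log units; beyond the scatter)). Against 3-chlorophenyl the step stays within the scatter (a 1.7-fold lower number from compound 3 to compound 4 (0.23 log units; within the scatter)), so compound 3 and compound 4 cannot be told apart, and the effect of this change depends on which group it replaces. Nothing measured here accounts for these steps.

Still open, going by these compounds, is whether the trifluoromethyl group itself matters or its place on the phenyl ring. Also open, on these data alone, is how this nitrogen would respond to a phenyl ring carrying an amine or a carboxylic acid, or to a group with no aromatic ring, such as a short alkyl chain.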